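Rho Kinase Inhibitors: Swapping the Amide Aryl Group

A few compounds are considered here, and "the series" means these few. Any claim that something is new, unique, unknown or untested is made for them only; others in the source may bear on it.

Compound 1, `O=C(COc1ccc2c(=O)ccoc2c1)Nc1cccc(NC(=O)c2ccc(OC(F)(F)F)cc2)c1`, gives 869 nM in an assay on isolated protein for inhibition of Rho-associated protein kinase 1 (Homo sapiens), read by scintillation counting, radiometric assay and 33P incorporation, with a stated time of 40 min, in the presence of a further agent that is not named here; on this read-out lower numbers stand for stronger inhibition and higher numbers for weaker inhibition.
Compound 2, `COC(=O)c1ccc(C(=O)Nc2cccc(NC(=O)COc3ccc4c(=O)ccoc4c3)c2)cc1`, gives 72 nM in this assay.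
Compound 3, `CC(C)(C)c1cc(C(=O)Nc2cccc(NC(=O)COc3ccc4c(=O)ccoc4c3)c2)no1`, gives 101 nM in this assay.

Compound 3 stands second of the three numbers in this assay, with compound 2 nearest at a 1.4-fold higher number from compound 2 to compound 3 (0.15 log units; within the scatter) and compound 1 furthest at an 8.6-fold lower number from compound 1 to compound 3 (0.93 log units; beyond the scatter). Compound 4, `Nc1cccc(C(=O)Nc2cccc(NC(=O)COc3ccc4c(=O)ccoc4c3)c2)c1`, is not yet measured; it differs from compound 3 by 3-aminophenyl in place of 5-(tert-butyl)-1,2-oxazol-3-yl on a carbonyl carbon. The steps that changed the group on this carbonyl carbon were an 8.6-fold lower number from compound 1 to compound 3 (0.93 log units; beyond the scatter) and a 1.4-fold higher number from compound 2 to compound 3 (0.15 log units; within the scatter), and the ring substituent swap was a 12-fold lower number from compound 1 to compound 2 (1.08 log units; beyond the scatter); the new ring carries a substituent not seen before. The expected step is a 1.5-fold higher number from compound 3 to compound 4 (0.17 log units; within the scatter), not beyond the scatter. Compound 4 is estimated at 150 nM, within 40 nM to 600 nM.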

Compound 4, half-maximal inhibitory concentration: 670 nM
Compound 4: middle estimate off by 4.5-fold (0.65 log units), on the low side; the measured number lies above the stated range.
By their numbers in this assay, from the lowest: compounds 2 and 3 (each within the scatter of the next); then compounds 4 and 1 (each within the scatter of the next).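

In this assay, a new aromatic group on this carbonyl carbon does not by itself keep the lower numbers seen so far: the change to 3-aminophenyl brings a 6.6-fold higher number from compound 3 to compound 4 (0.82 log units; beyond the scatter) and a 9.3-fold higher number from compound 2 to compound 4 (0.97 log units; beyond the scatter). Set against the 4-(trifluoromethoxy)phenyl group, it brings a 1.3-fold lower number from compound 1 to compound 4 (0.11 log units; within the scatter), so compound 1 and compound 4 cannot be told apart. Going by these compounds, whether a 4-aminophenyl group or an unsubstituted phenyl group on this carbonyl carbon would read closer to compound 2 or to compound 4 stays open. Nothing available gives a cause for these steps.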